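Repositioning the methoxy groups on the aryl substituent

The compounds below may be only part of what the source reports. "The series", "measured", "known", "first", "only" and "open" are said of these compounds alone.

Of the compounds shown here, three have been measured in an assay on CHO cells for antagonist activity at transient receptor potential cation channel subfamily V member 1 (Homo sapiens), read by FLIPR; a lower number here means a stronger inhibitor, a higher number a weaker inhibitor. Compound 1 `CC(C(=O)NCc1ccc(C(F)(F)F)cc1N1CCN(c2ccccc2)CC1)c1ccc(NS(C)(=O)=O)c(F)c1` gives 2 nM, compound 2 `CC(C(=O)NCc1ccc(C(F)(F)F)cc1OCc1ccccc1)c1ccc(NS(C)(=O)=O)c(F)c1` gives 0.9 nM, and compound 3 `COc1ccc(-c2cc(C(F)(F)F)ccc2CNC(=O)C(C)c2ccc(NS(C)(=O)=O)c(F)c2)cc1OC` gives 8.6 nM. Compound 3 therefore carries the highest number of the three: the change a 4.3-fold higher number from compound 1 to compound 3 (0.63 log units; beyond the scatter) and the change a 9.6-fold higher number from compound 2 to compound 3 (0.98 log units; beyond the scatter) both run upward and beyond the scatter, while a 2.2-fold lower number from compound 1 to compound 2 (0.35 log units; beyond the scatter) is a modest downward step.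

Compound 4 `COc1cc(OC)cc(-c2cc(C(F)(F)F)ccc2CNC(=O)C(C)c2ccc(NS(C)(=O)=O)c(F)c2)c1` keeps the core of compound 3 and the same atoms; the change is 3,5-dimethoxyphenyl in place of 3,4-dimethoxyphenyl on an aromatic carbon. Among the measured compounds shown here, none of the measured steps moves a methoxy group within a ring; every measured step exchanges the whole substituent on the aromatic carbon. For the measured compounds named here, the only direct information is that the dimethoxyphenyl-bearing compound 3 sits at the high end of the measured range. Absent a step of the same kind, a change in this assay beyond the scatter is not expected, though the direction is open. Compound 4 is estimated at 10 nM, with a range of 3 nM to 35 nM, which means an expected step of a 1.2-fold higher number from compound 3 to compound 4 (0.07 log units; within the scatter).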

Compound 4, inhibition constant: 5.8 nM
Estimate against measurement, compound 4: 1.7-fold (0.24 log units) above; the range from low to high includes it.
By their numbers in this assay, from the lowest: compound 2; then compound 1; then compounds 4 and 3 (each within the scatter of the next).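

Moving one methoxy group within the ring is the only step of its kind here, and it gives a 1.5-fold lower number from compound 3 to compound 4 (0.17 log units; within the scatter) in this assay. On this aromatic carbon, the 3,4-dimethoxyphenyl and 3,5-dimethoxyphenyl groups therefore cannot be told apart in this assay. The exchanges of whole substituents still read beyond the scatter, with a 6.4-fold higher number from compound 2 to compound 4 (0.81 log units; beyond the scatter) and a 2.9-fold higher number from compound 1 to compound 4 (0.46 log units; beyond the scatter), and no measurement on hand accounts for these numbers.

Open, from the compounds shown here alone, is what a single methoxy group, or an amine or a carboxylic acid in place of the methoxy groups, would give on this aryl ring. Also open, going by these compounds, is whether the number of compound 2 depends on the oxygen of its benzyloxy group or on its phenyl ring.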